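Trading the difluorinated ring for plain cyclohexyl

This account rests on a few compounds, and the source may have more. Where it says the series, first, only, none or still open, it means among the compounds named here.

Compound 1 `CC(C)C[C@H](NC(=O)OC1CCC(F)(F)CC1)C(=O)N[C@H](C=O)C[C@@H]1CCNC1=O`: in a toxicity assay on Huh-7 cells (Homo sapiens) for cytotoxicity (a higher number here means that more compound is tolerated, a lower number that less compound is tolerated), compound 1 gives > 100000 nM, a limit of the assay rather than a number.
Compound 2 `CC(C)C[C@H](NC(=O)OC1CCCCC1)C(=O)N[C@H](C=O)C[C@@H]1CCNC1=O`: in this assay compound 2 gives > 100000 nM, again only a limit.
Compound 3 `CC(C)C[C@H](NC(=O)OC1CCC(F)(F)CC1)C(=O)N[C@@H](C[C@@H]1CCNC1=O)C(O)S(=O)(=O)O`: in this assay compound 3 gives > 100000 nM, also a limit.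

Compound 3 therefore stands at the top of what this assay can report, and every value shown sits there (the limit of > 100000 nM in this assay, at which 3 of the 3 values shown sit). The change to compound 4 `CC(C)C[C@H](NC(=O)OC1CCCCC1)C(=O)N[C@@H](C[C@@H]1CCNC1=O)C(O)S(=O)(=O)O` is cyclohexyl in place of 4,4-difluorocyclohexyl on an oxygen next to a carbonyl group. The same exchange was made once before, but a step that the two limits leave unreadable from compound 1 to compound 2, and likewise a step that the two limits leave unreadable from compound 1 to compound 3. No readable step exists to build on, so no shift beyond the scatter is expected. Compound 4 is estimated at 150000 nM, between 50000 nM and 500000 nM, which means an expected step that the limit leaves unreadable from compound 3 to compound 4, most likely reported once more as a limit.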

Compound 4, half-maximal cytotoxic concentration: > 100000 nM
Compound 4: a limit, no number; the forecaster's own chance of this, stated with the estimate: 85%; the middle value lies beyond the limit too.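

Compound 4 gives only a limit, so its steps from compound 2 and compound 3 cannot be read: the limit of > 100000 nM in this assay, at which 4 of the 4 values shown sit.

In this assay the compounds shown leave open how much of any of them these cells would tolerate before a measurable effect appears.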